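From cyclopentyl to 1H-pyrazol-5-yl on a carbonyl carbon

A few compounds are considered here, and "the series" means these few. Any claim that something is new, unique, unknown or untested is made for them only; others in the source may bear on it.

In a toxicity assay on THP-1 cells (Homo sapiens) for inhibition (on this read-out higher numbers stand for lower toxicity in this test and lower numbers for higher toxicity in this test), compound 3 (`COc1ccc(-c2cnc(NC(=O)C3CCCC3)n2C)cc1`) gives > 100000 nM as a limit of the assay and not a number. Compound 1 (`COc1ccc(-c2cnc(NC(=O)c3ccccc3O)n2C)cc1`) gives > 100000 nM as a limit too. Compound 2 (`COc1ccc(-c2cnc(NC(=O)C3CCNCC3)n2C)cc1`) gives > 100000 nM as a limit as well. Compound 3 therefore stands at the limit of > 100000 nM in this assay, at which 3 of the 3 values shown sit, and has no number of its own.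

Compound 4 (`COc1ccc(-c2cnc(NC(=O)c3ccn[nH]3)n2C)cc1`) carries 1H-pyrazol-5-yl in place of cyclopentyl on a carbonyl carbon, and the change counts as 1H-pyrazol-5-yl in place of cyclopentyl on a carbonyl carbon in the structure. The measured steps bearing on it exchange groups at that same place. They are a step that the two limits leave unreadable from compound 1 to compound 3 and a step that the two limits leave unreadable from compound 2 to compound 3 and a step that the two limits leave unreadable from compound 1 to compound 2 in turn, so none offers a size to carry over. No step beyond the scatter is expected, and no direction can be given. The expected change is a number no higher from compound 3 to compound 4 (the limit leaves the size open) in this assay on this reading. For compound 4 the estimate is 100000 nM as the expected value, with an expected range from 50000 nM to 200000 nM in all.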

Compound 4, half-maximal cytotoxic concentration: > 100000 nM
Compound 4 was reported as a limit; the forecaster's own chance of this, stated with the estimate: 85%; the middle value lies on the limit itself.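

In this assay compound 4 gives > 100000 nM, a limit of the assay and not a number, so its steps from compound 1, compound 2 and compound 3 cannot be read. The compounds shown leave open whether the group on the carbonyl carbon changes the result in this assay, for all of them share one reading: the limit of > 100000 nM in this assay, at which 4 of the 4 values shown sit.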